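Isopropyl in place of bromo on the benzyl ring

The source may report more compounds than this note shows. Statements on the series, on what has been measured and on what is new or still open speak of the compounds shown alone.

Compound 2 `O=C(CCCC1CCN(Cc2ccc(Br)cc2)CC1)c1ncco1` is the compound with the lower of the two numbers recorded so far in an assay on isolated protein for inhibition of Fatty-acid amide hydrolase 1 (Homo sapiens) (a higher number here means a weaker inhibitor, a lower number a stronger inhibitor), where compound 2 gives 45 nM. For the measured compounds named here, its only neighbour is compound 1 `O=C(CCCC1CCN(Cc2ccc(Cl)cc2)CC1)c1ncco1`, which in this assay gives 66 nM; the step of a 1.5-fold lower number from compound 1 to compound 2 (0.17 log units; within the scatter) is within the scatter, so the two compounds cannot be ordered. Compound 3 `CC(C)c1ccc(CN2CCC(CCCC(=O)c3ncco3)CC2)cc1` differs from compound 2 by isopropyl in place of bromo on an aromatic carbon. Going by the values given here, the single measured step, from chloro to bromo, is the only one that bears on a change at this aromatic carbon, and it was within the scatter; no measured step covers a halogen giving way to an isopropyl group. The expected step of a 1.3-fold higher number from compound 2 to compound 3 (0.12 log units; within the scatter) is therefore small and uncertain in direction. Compound 3 is estimated at 60 nM in this assay, with a range from 20 nM to 180 nM.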

Compound 3, half-maximal inhibitory concentration: 3.6 nM
Compound 3: the middle estimate sits 17-fold (1.22 log units) above what was measured; the measured number lies below the stated range.
By their numbers in this assay, from the lowest: compound 3; then compounds 2 and 1 (each within the scatter of the next).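

In this assay there is a 13-fold lower number from compound 2 to compound 3 (1.10 log units; beyond the scatter) with isopropyl in place of bromo, and an 18-fold lower number from compound 1 to compound 3 (1.26 log units; beyond the scatter) with isopropyl in place of chloro. This aromatic carbon, which showed no readable difference between the two halogens, is therefore not indifferent to what it carries: the change to 3 carbon atoms separates compound 3 clearly from both halogen compounds. Nothing available explains this large step.

On these data alone, whether methyl, tert-butyl or an amine on this carbon would give a number close to that of compound 3 or to those of the halogen compounds stays open. So does whether isopropyl would keep this advantage on a core with a longer chain.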